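A few compounds are considered here, and "the series" means these few. Any claim that something is new, unique, unknown or untested is made for them only; others in the source may bear on it.

Compound 1, `CN(CC1CCN(CCCc2c[nH]c3ccc(-n4cnnc4)cc23)CC1)C(=O)Nc1ccccc1`, 6.2 nM
Compound 2, `c1ccc(CNCC2CCN(CCCc3c[nH]c4ccc(-n5cnnc5)cc34)CC2)cc1`, 28 nM
Compound 3, `CN(Cc1ccco1)C1CCN(CCCc2c[nH]c3ccc(-n4cnnc4)cc23)CC1`, 89 nM

In an assay on CHO cells for displacement of a labelled ligand from 5-hydroxytryptamine receptor 1B (Homo sapiens) (a lower number here means a stronger inhibitor, a higher number a weaker inhibitor), compound 3 stands highest of the three numbers; the nearest is compound 2, a step of a 3.2-fold higher number from compound 2 to compound 3 (0.50 log units; beyond the scatter), and the furthest is compound 1.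

Compound 4, `c1ccc2c(c1)CCC2NCC1CCN(CCCc2c[nH]c3ccc(-n4cnnc4)cc23)CC1`, has not been measured. It differs from compound 3 by ((2,3-dihydro-1H-inden-1-yl)amino)methyl in place of ((furan-2-yl)methyl)(methyl)amino on a saturated ring carbon; what enters carries one hydrogen-bond donor, and a methylene again links the amine to the ring carbon, as in compound 2. The step of a 3.2-fold higher number from compound 2 to compound 3 (0.50 log units; beyond the scatter) bears on this most directly, since compound 4 returns to that arrangement; the step of a 4.5-fold higher number from compound 1 to compound 2 (0.65 log units; beyond the scatter) bears on it less.

Compound 4 is therefore expected to give a lower number in this assay than compound 3, a step of about a 3.6-fold lower number from compound 3 to compound 4 (0.55 log units; beyond the scatter). The estimate for compound 4 is 25 nM, with a range from 8 nM to 80 nM.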

Compound 4, half-maximal inhibitory concentration: 25 nM
Compound 4: the middle estimate sits on the measured number at the digits printed; the range from low to high includes it.
By their numbers in this assay, from the lowest: compound 1; then compounds 4 and 2 (each within the scatter of the next); then compound 3.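

In this assay, the step from benzyl to 2,3-dihydro-1H-inden-1-yl on the amine nitrogen is a 1.1-fold lower number from compound 2 to compound 4 (0.05 log units; within the scatter), so this nitrogen carries either group with no difference beyond the scatter. The change from compound 3 gives a 3.6-fold lower number from compound 3 to compound 4 (0.55 log units; beyond the scatter), while a 4.0-fold higher number from compound 1 to compound 4 (0.61 log units; beyond the scatter) shows that this amine does not match the methyl(phenylcarbamoyl)amino group of compound 1. No measurement here accounts for these differences.

The linking methylene, amine hydrogen and ring all change together between compound 3 and compound 4, and the compounds shown do not separate them. Going by these compounds, the effect of a methyl group on the amine nitrogen of compound 4 also remains open.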